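The source may hold more compounds than are shown below. What is called first, only, known or untested is meant among the compounds shown, and "the series" means these compounds.

The series shares one core, seen in compound 1 `CC(C)c1cc(OCC(=O)[C@H](CC(=O)O)NC(=O)[C@@H](NC(=O)COc2cccc3ccccc23)C(C)C)no1`, compound 2 `CC(C)[C@H](NC(=O)COc1cccc2ccccc12)C(=O)N[C@@H](CC(=O)O)C(=O)CSc1nc2ccccc2[nH]1` and compound 3 `CC(C)[C@H](NC(=O)COc1cccc2ccccc12)C(=O)N[C@@H](CC(=O)O)C(=O)COc1nc2ccccc2[nH]1`. In a functional assay on Jurkat cells (Homo sapiens) for inhibition (a higher number here means a weaker inhibitor, a lower number a stronger inhibitor), compound 1 reaches only a limit, > 200000 nM. Compound 2 likewise gives only a limit in this assay, > 200000 nM. Compound 3 also gives nothing more than a limit in this assay, > 200000 nM. Compound 3 therefore stands at the limit of > 200000 nM in this assay, at which 3 of the 3 values shown sit, and no measured number sets it apart from its two companions. The steps between them, a step that the two limits leave unreadable from compound 1 to compound 2, a step that the two limits leave unreadable from compound 1 to compound 3 and a step that the two limits leave unreadable from compound 2 to compound 3, cannot be read in size or direction.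

Compound 4 `CC(C)[C@H](NC(=O)COc1cccc2ccccc12)C(=O)N[C@@H](CC(=O)O)C(=O)CSc1nccc(C(F)(F)F)n1` differs from compound 3 by (4-(trifluoromethyl)pyrimidin-2-yl)sulfanyl in place of (1H-benzimidazol-2-yl)oxy on a saturated chain carbon bound to a carbonyl carbon. The measured steps that touch this change are a step that the two limits leave unreadable from compound 2 to compound 3 and a step that the two limits leave unreadable from compound 1 to compound 3, both of which exchange a group at the same place, and both are unreadable, so no size or direction can be drawn for compound 4 in this assay. Compound 4 is thus expected to remain near the limit, with a number no higher from compound 3 to compound 4 (the limit leaves the size open) estimated as a step of no readable size. Compound 4 is estimated at 200000 nM, within 50000 nM to 400000 nM, and most likely reported again only as a limit.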

Compound 4, half-maximal inhibitory concentration: > 200000 nM
Compound 4 gave a limit, no number; the forecaster's own chance of this, stated with the estimate: 75%; the middle value sits exactly at the limit.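

Compound 4, like compound 1, compound 2 and compound 3, gives only a limit, so none of the steps among them can be read: the limit of > 200000 nM in this assay, at which 4 of the 4 values shown sit.

The compounds shown leave open whether any group on this saturated chain carbon bound to a carbonyl carbon would give a measurable number in this assay.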